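The source may report more compounds than this note shows. Statements on the series, on what has been measured and on what is new or still open speak of the compounds shown alone.

In a functional assay on HCT-116 cells (Homo sapiens) for antiproliferative activity, read by WST assay, with a stated time of 72 h (on this read-out higher numbers stand for weaker inhibition of growth and lower numbers for stronger inhibition of growth), compound 1 (`O=C(NO)c1cnc(N2C[C@@H]3[C@H](C2)[C@H]3NS(=O)(=O)c2ccc3ccccc3c2)nc1`) gives 440 nM. Compound 3 (`CCCCc1ccc(CN[C@H]2[C@@H]3CN(c4ncc(C(=O)NO)cn4)C[C@@H]32)cc1`) gives 410 nM, which lies within the scatter of the value for compound 1. Compound 2 (`O=C(NO)c1cnc(N2C[C@@H]3[C@H](C2)[C@H]3NS(=O)(=O)c2cccs2)nc1`) gives > 10000 nM, which is a limit of the assay and not a number. Compound 4 (`CN([C@H]1[C@@H]2CN(c3ncc(C(=O)NO)cn3)C[C@@H]21)S(=O)(=O)c1ccc2ccccc2c1`) differs from compound 1 by methyl in place of hydrogen on a sulfonamide nitrogen, with methyl in place of hydrogen on a sulfonamide nitrogen. For the measured compounds named here, no measured step changes that nitrogen. Going by the values given here, the one measured step, an at least 22-fold higher number from compound 1 to compound 2 (1.35 log units; beyond the scatter), lies on the sulfonyl sulfur, so it shows that this series can respond strongly but bears only indirectly on the methyl change. Compound 3, which carries no sulfonamide, still gives 410 nM, so a sulfonamide hydrogen is not needed for a value of this size. No shift beyond the scatter is therefore expected in this assay, with a slight lean towards a higher number. The expected step is a 1.4-fold higher number from compound 1 to compound 4 (0.13 log units; within the scatter). For compound 4 the estimated value is 600 nM, with an expected range of 200 nM to 2500 nM.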

Compound 4, concentration for 50% growth inhibition: 1000 nM
Beside the measured number, compound 4's estimate is 1.7-fold (0.22 log units) below it; the measured number falls inside the stated range.
By their numbers in this assay, from the lowest: compounds 3 and 1 (each within the scatter of the next); then compound 4. At a limit, above all of these: compound 2.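

In this assay, for the compounds shown here, the sulfonamide nitrogen proves to be a position that responds to substitution: methyl in place of hydrogen gives a 2.3-fold higher number from compound 1 to compound 4 (0.36 log units; beyond the scatter), the first measured step at this nitrogen. The step is modest, and compound 4 still gives a measured number rather than a limit, so this nitrogen tolerates methyl with a small loss of growth inhibition. The compounds shown offer nothing that accounts for this step.

What the compounds shown leave open is whether a larger group on this nitrogen, such as ethyl or a longer chain ending in an amine, would move the number further. From the compounds shown here alone, it is also open whether the same methyl change would have a step of similar size on a sulfonamide carrying a group other than naphthalen-2-yl.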